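From methylsulfanyl to propoxy at the assay limit

A few compounds are considered here, and "the series" means these few. Any claim that something is new, unique, unknown or untested is made for them only; others in the source may bear on it.

In an ADME assay on Akata cells (Homo sapiens) for cytotoxicity, with a stated time of 7 days (on this read-out lower numbers stand for higher toxicity in this test and higher numbers for lower toxicity in this test), compound 1 (`COCCOc1nc(N)nc2c1ncn2/C=C1/CC1(CO)CO`) gives > 20000 nM as a limit. Compound 2 (`CCCCCCCCOc1nc(N)nc2c1ncn2/C=C1/CC1(CO)CO`) gives > 20000 nM as a limit too. Compound 3 (`CSc1nc(N)nc2c1ncn2/C=C1/CC1(CO)CO`) likewise has only > 20000 nM as a limit and no number. Compound 4 (`CCCOc1nc(N)nc2c1ncn2/C=C1/CC1(CO)CO`) has propoxy in place of methylsulfanyl on an aromatic carbon. For the measured compounds named here, three steps bear on this (a step that the two limits leave unreadable from compound 1 to compound 3; a step that the two limits leave unreadable from compound 2 to compound 3; a step that the two limits leave unreadable from compound 1 to compound 2) and none has a readable size. Because of the limit of > 20000 nM in this assay, at which 3 of the 3 values shown sit, across 2-methoxyethoxy, octyloxy and methylsulfanyl in compound 1, compound 2 and compound 3, no step beyond the scatter is expected in this assay in either direction. The expected change is a step that the limit leaves unreadable from compound 3 to compound 4 and no more. Compound 4 is estimated at 25000 nM with a range from 12000 nM to 50000 nM and will probably be reported only as a limit.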

Compound 4, half-maximal cytotoxic concentration: > 20000 nM
Compound 4: a limit, no number; the forecaster's own chance of this, stated with the estimate: 85%; the middle value does not contradict the limit.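

No step can be read between compound 4 and compound 1, compound 2 or compound 3 in this assay, because all four stop at the same point: the limit of > 20000 nM in this assay, at which 4 of the 4 values shown sit.

The compounds shown leave open whether the groups on the aromatic carbon differ at all in this test.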